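This account rests on a few compounds, and the source may have more. Where it says the series, first, only, none or still open, it means among the compounds named here.

Compound 2 `COC(=O)C[C@H](NC(=O)OC(C)(C)C)C(=O)N(Cc1ccc(F)cc1)C1(C(=O)NCc2ccccc2)CCN(Cc2ccccc2)CC1` carries a fluoro in place of hydrogen on an aromatic carbon relative to compound 1 `COC(=O)C[C@H](NC(=O)OC(C)(C)C)C(=O)N(Cc1ccccc1)C1(C(=O)NCc2ccccc2)CCN(Cc2ccccc2)CC1`. In an ADME assay on MDCK cells (Canis lupus familiaris) for cytotoxicity, read by microscopy, with a stated time of 72 h (on this read-out lower numbers stand for higher toxicity in this test and higher numbers for lower toxicity in this test), compound 1 gives only a limit, > 100000 nM. Compound 2 likewise gives only a limit in this assay, > 100000 nM. The step that the two limits leave unreadable from compound 1 to compound 2 therefore cannot be read. Compound 3 `COC(=O)C[C@H](NC(=O)OC(C)(C)C)C(=O)N(Cc1ccc(F)cc1)C1(C(=O)NCc2ccccc2)CCN(c2ccccc2)CC1`, with phenyl in place of benzyl on an amine nitrogen in a ring, gives 20000 nM in this assay, and the step of an at least 5.0-fold lower number from compound 2 to compound 3 (0.69 log units; beyond the scatter) is the only readable one among the three. Compound 2 thus stands at the limit of > 100000 nM in this assay, at which 2 of the 3 values shown sit. Compound 4 `COC(=O)C[C@H](NC(=O)OC(C)(C)C)C(=O)N(Cc1ccc(F)cc1)C1(C(=O)NC2CCCCC2)CCN(Cc2ccccc2)CC1` differs from compound 2 by cyclohexyl in place of benzyl on an amide-type nitrogen. Among the measured compounds shown here, neither measured step touches the amide-type nitrogen, so no step among the three compounds bears on this change, and the limit for compound 2 leaves no room to read a rise. A step of no size beyond the scatter is expected, a number no higher from compound 2 to compound 4 (the limit leaves the size open). Compound 4 is therefore estimated at 100000 nM, with a range from 30000 nM to 300000 nM, and most likely again reported as a limit.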

Compound 4, minimum cytotoxic concentration: 100000 nM
Compound 4: the middle estimate sits on the measured number at the digits printed, and the stated range covers the measured number.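

Among the compounds shown here, at this position, the first change to the amide-type nitrogen shows that cyclohexyl in place of benzyl still leaves toxicity in this assay at the top of the range tested, with a number no higher from compound 2 to compound 4 (the limit leaves the size open). Unlike compound 2, compound 4 gives an exact number, 100000 nM, so swapping the aromatic ring for a non-aromatic ring of carbon only does not produce a step like the one seen on the ring nitrogen with compound 3. The size of this new step cannot be read, and compound 2 remains a limit: the limit of > 100000 nM in this assay, at which 2 of the 4 values shown sit.

The compounds shown leave open whether a chain ending in an amine or a carboxylic acid on the amide-type nitrogen would lower the number. They also leave open how cyclohexyl behaves alongside the phenyl of compound 3.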